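Aryl variation on the amine nitrogen of the shared core

A few compounds are considered here, and "the series" means these few. Any claim that something is new, unique, unknown or untested is made for them only; others in the source may bear on it.

The three measured compounds share one core and differ only in the aryl group on the amine nitrogen. Compound 1 `CCOc1ccccc1NCn1nc(-c2ccc3c(c2)OCCO3)oc1=S` gives 5280 nM in a functional assay, with a stated time of 6 min; on this read-out lower numbers stand for stronger inhibition and higher numbers for weaker inhibition. Compound 2 `S=c1oc(-c2ccc3c(c2)OCCO3)nn1CNc1ccccc1Cl` gives 7230 nM in this assay, and compound 3 `S=c1oc(-c2ccc3c(c2)OCCO3)nn1CNc1cc(Cl)ccc1Cl` gives 5420 nM in this assay. Compound 3 thus holds the second highest of the three numbers; its nearest neighbour is compound 1, by the step of a 1.0-fold higher number from compound 1 to compound 3 (0.01 log units; within the scatter), and the furthest is compound 2, by the step of a 1.3-fold lower number from compound 2 to compound 3 (0.13 log units; within the scatter).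

Compound 4 `O=[N+]([O-])c1ccccc1NCn1nc(-c2ccc3c(c2)OCCO3)oc1=S` has not yet been measured. It differs from compound 3 by 2-nitrophenyl in place of 2,5-dichlorophenyl on an amine nitrogen. Among the compounds with values here, the steps that bear on this change are all those made on the aryl group at this nitrogen: a 1.4-fold higher number from compound 1 to compound 2 (0.14 log units; within the scatter), a 1.3-fold lower number from compound 2 to compound 3 (0.13 log units; within the scatter) and a 1.0-fold higher number from compound 1 to compound 3 (0.01 log units; within the scatter). None of these exchanges moved the number beyond the scatter of this assay. On that basis no step beyond the scatter is expected from compound 3 to compound 4, and the step is estimated at a 1.0-fold higher number from compound 3 to compound 4 (0.01 log units; within the scatter). For compound 4 the expected value in this assay is 5600 nM, with a range from 2500 nM to 12500 nM.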

Compound 4, half-maximal inhibitory concentration: 10900 nM
For compound 4 the middle estimate is 1.9-fold (0.29 log units) below the measured one; measured number inside the range.
By their numbers in this assay, from the lowest: compounds 1, 3, 2 and 4 (each within the scatter of the next, the first and the last beyond it).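

In this assay, within the data shown here, nitro in place of ethoxy gives the first step on this aryl group that lies beyond the scatter, though only modestly (a 2.1-fold higher number from compound 1 to compound 4 (0.31 log units; beyond the scatter)). Against the two chloro compounds, the 2-nitrophenyl group stays within the scatter (a 2.0-fold higher number from compound 3 to compound 4 (0.30 log units; within the scatter); a 1.5-fold higher number from compound 2 to compound 4 (0.18 log units; within the scatter)), so it separates clearly only from the 2-ethoxyphenyl group of compound 1. No evidence at hand accounts for this step.

Going by these compounds, whether an amine, a carboxylic acid or a nitrile on the aromatic ring would move the number further remains open, as does a cyclohexyl group in place of the aryl group on the amine nitrogen. The compounds shown also leave open how the number responds to changes elsewhere on the shared core.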